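The source may hold more compounds than are shown below. What is called first, only, known or untested is meant among the compounds shown, and "the series" means these compounds.

Of the compounds shown here, three built on a common core have been tested in an assay on isolated protein (Sus scrofa) for inhibition of 2-Hydroxyacid oxidase 1 (Homo sapiens); on this read-out higher numbers stand for weaker inhibition and lower numbers for stronger inhibition. Compound 1, `O=C(/C=C/c1ccccc1)CC(=O)C(=O)O`, gives 19000 nM. Compound 2, `CCCCCCCCCc1ccc(C(=O)CC(=O)C(=O)O)cc1`, gives 600 nM. Compound 3, `O=C(O)C(=O)CC(=O)c1ccc(-c2ccccc2)cc1`, gives 1100 nM. Among these three numbers compound 3 stands second highest: its nearest neighbour is compound 2, a gap within the usual scatter, so the two cannot be told apart, while compound 1 lies far above it, a gap well beyond the scatter.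

Compound 4, `CSc1ccc(-c2ccc(C(=O)CC(=O)C(=O)O)cc2)cc1`, differs from compound 3 in one place: methylsulfanyl in place of hydrogen on an aromatic carbon. Within the data shown here, no measured pair shows this same change, so its effect must be judged from the structures alone. Compound 2 shows that a long group at the far end of the core goes with a low number, because it gives 600 nM, and compound 4 likewise extends the far end. The expected step is therefore small and toward a lower number, a 1.6-fold lower number from compound 3 to compound 4 (0.20 log units; within the scatter), not clearly beyond the scatter. Compound 4 is estimated at 700 nM, within a range from 250 nM to 2500 nM.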

Compound 4, half-maximal inhibitory concentration: 160 nM
Beside the measured number, compound 4's estimate is 4.4-fold (0.64 log units) above it; the measured number lies below the stated range.
By their numbers in this assay, from the lowest: compound 4; then compounds 2 and 3 (each within the scatter of the next); then compound 1.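

In this assay, placing methylsulfanyl on an aromatic carbon, para to a large group, gives a 6.9-fold lower number from compound 3 to compound 4 (0.84 log units; beyond the scatter), a step beyond the usual scatter toward stronger inhibition. Among these compounds, this is the first change in a single place that can be read, and it shows that this position responds to a substituent of only 2 heavy atoms. No measurement at hand explains how the change produces this step.

From the compounds shown here alone, it remains open whether the sulfur matters or whether a methoxy group, a methyl group or a chlorine atom at the same place would give a similar step. Also open, going by these compounds, is how a longer chain on the sulfur, such as ethylsulfanyl, or a methylsulfonyl group there would compare.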